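Cyclopentylmethyl in Place of Cyclopropylmethyl

The source may hold more compounds than are shown below. What is called first, only, known or untested is meant among the compounds shown, and "the series" means these compounds.

In a functional assay on HL-60 cells (Homo sapiens) for inhibition (a higher number here means a weaker inhibitor, a lower number a stronger inhibitor), compound 1 (`COc1ccc(-c2cc(=O)n(Cc3cccnc3)nc2-c2ccc(OC)cc2)cc1`) gives 430 nM with (pyridin-3-yl)methyl on an aromatic nitrogen. Compound 2 (`COc1ccc(-c2cc(=O)n(C(C)C)nc2-c2ccc(OC)cc2)cc1`) gives 1320 nM with isopropyl in that place, and compound 3 (`COc1ccc(-c2cc(=O)n(CC3CC3)nc2-c2ccc(OC)cc2)cc1`) gives 1800 nM with cyclopropylmethyl. The step of a 1.4-fold higher number from compound 2 to compound 3 (0.13 log units; within the scatter) lies within the scatter, so compound 3 cannot be told apart from compound 2. The steps of a 4.2-fold higher number from compound 1 to compound 3 (0.62 log units; beyond the scatter) and a 3.1-fold higher number from compound 1 to compound 2 (0.49 log units; beyond the scatter) are modest but beyond the scatter, leaving compound 3 a weaker inhibitor than compound 1.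

Compound 4 (`COc1ccc(-c2cc(=O)n(CC3CCCC3)nc2-c2ccc(OC)cc2)cc1`) differs from compound 3 by one change: cyclopentyl in place of cyclopropyl on a saturated chain carbon bound to an aromatic nitrogen with cyclopentyl in place of cyclopropyl on a saturated chain carbon bound to an aromatic nitrogen. Among the measured compounds shown here, no measured pair varies ring size alone. For the measured compounds named here, both modest steps involve the loss of pyridin-3-yl, which compound 4 also lacks, while the one step between groups without it stays within the scatter. No step beyond the scatter is therefore expected, with an estimated 1.3-fold lower number from compound 3 to compound 4 (0.11 log units; within the scatter) as the likely outcome. In this assay compound 4 is expected at an estimated 1400 nM (range 600 nM to 3200 nM).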

Compound 4, half-maximal inhibitory concentration: 110 nM
Compound 4: the middle estimate sits 13-fold (1.10 log units) above what was measured; the whole stated range lies above it.
By their numbers in this assay, from the lowest: compound 4; then compound 1; then compounds 2 and 3 (each within the scatter of the next).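

In this assay, among the compounds shown here, the group on the aromatic nitrogen can move the number much further than the earlier compounds showed: enlarging the ring alone, cyclopentyl in place of cyclopropyl, gives a 16-fold lower number from compound 3 to compound 4 (1.21 log units; beyond the scatter) at this place, and replacing isopropyl gives a 12-fold lower number from compound 2 to compound 4 (1.08 log units; beyond the scatter) as well. Pyridin-3-yl is also not required for the lowest number in this set, as cyclopentylmethyl, which holds carbon only, gives a 3.9-fold lower number from compound 1 to compound 4 (0.59 log units; beyond the scatter) against the (pyridin-3-yl)methyl group. No available measurement explains why the larger ring lowers the number.

As far as these compounds go, only the three-membered and five-membered rings can be compared here, so it remains open whether cyclobutylmethyl would give an intermediate number or whether cyclohexylmethyl would lower it further. From the compounds shown here alone, the effect of a longer chain, such as 2-cyclopentylethyl, on the aromatic nitrogen also remains unknown.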